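This account rests on a few compounds, and the source may have more. Where it says the series, first, only, none or still open, it means among the compounds named here.

Measured in a physicochemical assay for solubility, in phosphate buffer, with a stated time of 18 h, at pH 7.4; a higher number here means a more soluble compound, a lower number a less soluble compound:
- compound 1 `COc1cc2ncnc(-n3nc(-c4ccccn4)nc3N)c2cc1[N+](=O)[O-]`: 2000 nM
- compound 2 `Nc1nc(-c2ccccn2)nn1-c1ncnc2cc(N3CCNCC3)c([N+](=O)[O-])cc12`: 4000 nM
- compound 3 `COc1cc2c(-n3nc(-c4ccccn4)nc3N)ncnc2cc1O`: 44000 nM

Compound 1 sits at the bottom of these three numbers together with compound 2, and compound 3 stands well above both.

The next compound is compound 4 `COc1cc2ncnc(-n3nc(-c4ccccn4)nc3N)c2cc1OCCCN1CC(C)OC(C)C1`, not yet measured. Its change from compound 1 is 3-(2,6-dimethylmorpholin-4-yl)propoxy in place of nitro on an aromatic carbon: 3-(2,6-dimethylmorpholin-4-yl)propoxy in place of nitro, ortho to a methoxy group.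

Going by the values given here, no measured step makes this change. Among the compounds with values here, the one available step, a 2.0-fold higher number from compound 1 to compound 2 (0.30 log units; within the scatter), replaces methoxy and keeps nitro, so it bears only indirectly and shows nothing beyond the scatter. Within the data shown here, the closest hint is compound 3 at 44000 nM, which also carries no nitro, but no step links it to compound 1 and its methoxy sits elsewhere.

A rise beyond the scatter in this assay is therefore expected, though this rests on thin evidence. The expected change is a 10-fold higher number from compound 1 to compound 4 (1.00 log units; beyond the scatter). For compound 4 the estimate is 20000 nM, with an expected range of 5000 nM to 80000 nM.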

Compound 4, solubility: 8000 nM
Compound 4: the middle estimate sits 2.5-fold (0.40 log units) above what was measured; measured number inside the range.
By their numbers in this assay, from the lowest: compounds 1, 2 and 4 (each within the scatter of the next, the first and the last beyond it); then compound 3.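

In this assay, the aromatic carbon ortho to a methoxy group gives a first readable step when 3-(2,6-dimethylmorpholin-4-yl)propoxy replaces nitro: a 4.0-fold higher number from compound 1 to compound 4 (0.60 log units; beyond the scatter). The only earlier step from compound 1 changes the methoxy place and stays within the scatter, so this is the only step shown that leaves it. The entering group has 12 heavy atoms and a six-membered non-aromatic ring against 3 heavy atoms for nitro, and no measured evidence explains the size of the step.

One swap removes nitro and adds the chain, so the compounds shown do not separate the two. Also open, from the compounds shown here alone, is how a shorter alkoxy chain, or an open-chain amine in place of the 2,6-dimethylmorpholine, would read at this position.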